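The compounds below may be only part of what the source reports. "The series", "measured", "known", "first", "only" and "open" are said of these compounds alone.

Working notes on the series, read in a functional assay on CWR22R cells (Homo sapiens) for antiproliferative activity, read by propidium iodide staining, with a stated time of 96 h; a higher number here means a weaker inhibitor, a lower number a stronger inhibitor. Compound 1 (`CC(O)(COc1ccc(C(F)(F)F)cc1)C(=O)Nc1cccc(S(F)(F)(F)(F)F)c1`) gives 3600 nM and compound 2 (`CC(O)(COc1ccc(OC(F)(F)F)cc1)C(=O)Nc1cccc(S(F)(F)(F)(F)F)c1`) gives 12900 nM as the higher of the two numbers, which makes compound 2 the weaker inhibitor of this pair.

Compound 3 (`CC(O)(COc1ccc(C#N)cc1)C(=O)Nc1cccc(S(F)(F)(F)(F)F)c1`) keeps the shared core of compound 2 and carries cyano in place of trifluoromethoxy on an aromatic carbon. The carbon concerned sits para to a large group.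

Within the data shown here, only one measured step bears on this change, the exchange of trifluoromethyl for trifluoromethoxy on the same carbon (a 3.6-fold higher number from compound 1 to compound 2 (0.55 log units; beyond the scatter)). Among the measured compounds shown here, that step is modest, and no measured compound yet carries cyano, so it offers a guide to size more than to direction. With compound 2 at the top of the range so far (12900 nM), a modest move to a lower number is expected in this assay, no larger than the measured step. The expected step is (a 2.2-fold lower number from compound 2 to compound 3 (0.33 log units; beyond the scatter)). For compound 3 the estimated value is 6000 nM (expected range 2200 nM to 16000 nM).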

Compound 3, half-maximal inhibitory concentration: 32500 nM
The estimate for compound 3 lay 5.4-fold (0.73 log units) below the measured number, outside the stated range (above it).
By their numbers in this assay, from the lowest: compound 1; then compound 2; then compound 3.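

In this assay, the carbon para to a large group proves sensitive to a third substituent: cyano in place of trifluoromethoxy moves the read-out the weaker way (a 2.5-fold higher number from compound 2 to compound 3 (0.40 log units; beyond the scatter)), so compound 3 is the weakest inhibitor of the three. Cyano in place of trifluoromethyl gives the widest step yet seen at this carbon (a 9.0-fold higher number from compound 1 to compound 3 (0.96 log units; beyond the scatter)), and the order from the lowest number now runs trifluoromethyl, trifluoromethoxy, cyano, with each step beyond the usual scatter. No measurement at hand accounts for this order, so the three compounds rank these groups without explaining the ranking.

Three substituents on one shared core do not show whether any other group at this carbon, such as chlorine, a methyl group, an amine or a carboxylic acid, would give a number lower than that of compound 1 or would extend the trend towards weaker inhibition. Going by these compounds, it also remains open whether the same order of trifluoromethyl, trifluoromethoxy and cyano would hold if the shared core were changed elsewhere, or in any read-out other than this antiproliferative one.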